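The source may hold more compounds than are shown below. What is called first, only, known or untested is meant among the compounds shown, and "the series" means these compounds.

Of the compounds shown here, two built on a shared core have been measured in a functional assay on HEK293 cells for antagonist activity at Orexin receptor type 2 (Homo sapiens), read by FLIPR and calcium flux; a lower number here means a less potent compound, a higher number a more potent compound, by a factor of ten per unit of this negative logarithm. Compound 1 `O=C(c1cc(Cl)ccc1-c1ncccn1)N1CC2(CC2)C[C@H]1CNc1cc(C(F)(F)F)ccn1` gives 7.1 in this assay. Compound 2 `N#Cc1ccc(-c2ncccn2)c(C(=O)N2CC3(CC3)C[C@H]2CNc2ccc(C(F)(F)F)cn2)c1` gives 8.1 in this assay, the higher of the two numbers; its nearest neighbour is compound 1, which sits lower by a gap beyond the usual scatter. Compound 2 and compound 1 differ in more than one place, so their gap cannot be tied to any single change.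

Compound 3 `O=C(c1cc(Cl)ccc1-c1ncccn1)N1CC2(CC2)C[C@H]1CNc1ccc(C(F)(F)F)cn1` has not yet been measured in this assay. It differs from compound 2 in one place: chloro in place of cyano on an aromatic carbon. Compound 3 thus carries the chloro that compound 1 also carries, while keeping the remainder of compound 2 unchanged. Within the data shown here, no measured pair isolates this exchange, so the size of its step can only be expected, not read off. Among the measured compounds shown here, the expected step in this assay is a modest loss, a number 0.40 log units lower from compound 2 to compound 3 (beyond the scatter), because compound 1 gives 7.1 as the only chloro-bearing compound measured. Compound 3 is therefore estimated at 7.7, with a range from 7 to 8.4.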

Compound 3, negative logarithm of the antagonist equilibrium constant: 7.2
Compound 3: the middle estimate sits 0.50 log units above what was measured; the measured number falls inside the stated range.
By their numbers in this assay, from the lowest: compounds 1 and 3 (each within the scatter of the next); then compound 2.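

With the 5-(trifluoromethyl)pyridin-2-yl group held constant, the exchange of cyano for chloro, on the aromatic carbon para to a pyrimidin-2-yl group, is now isolated in this assay and gives a number 0.90 log units lower from compound 2 to compound 3 (beyond the scatter). The second single change, 5-(trifluoromethyl)pyridin-2-yl in place of 4-(trifluoromethyl)pyridin-2-yl on the amine nitrogen with chloro kept on the aromatic ring, gives a number 0.10 log units higher from compound 1 to compound 3 (within the scatter). Of these two changes, only the exchange at the aromatic carbon therefore moves the number beyond the scatter, and nothing available accounts for why this exchange carries that step.

The compounds shown leave open whether cyano holds the same advantage over chloro when the 4-(trifluoromethyl)pyridin-2-yl group sits on the amine nitrogen, since that exchange has been read with only one of the two groups. They also leave open how a fluoro, a methoxy or a plain hydrogen on the same aromatic carbon would stand against cyano and chloro in this assay.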